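From 4-fluorophenyl to 4-carboxyphenyl on a shared core

The compounds below may be only part of what the source reports. "The series", "measured", "known", "first", "only" and "open" are said of these compounds alone.

Of the compounds shown here, three with a shared core have been measured in a functional assay on A549 cells (Homo sapiens) for cytotoxicity, read by MTT assay, with a stated time of 48 h; a lower number here means a stronger inhibitor, a higher number a weaker inhibitor. Compound 3 `CC1(C)CCC[C@]2(C)[C@@H](CC[C@@](C)(O)/C=C/c3ccc(F)cc3)[C@](C)(O)CC[C@@H]12` gives 3100 nM, and compound 1 `Cc1cccc(C)c1/C=C/[C@](C)(O)CC[C@@H]1[C@@]2(C)CCCC(C)(C)[C@@H]2CC[C@@]1(C)O` gives 3340 nM. The gap between them is a 1.1-fold lower number from compound 1 to compound 3 (0.03 log units; within the scatter), so the two stand level. Compound 2 `CC1(C)CCC[C@]2(C)[C@@H](CC[C@@](C)(O)/C=C/c3ccc(Br)cc3)[C@](C)(O)CC[C@@H]12` gives 43200 nM, well apart from both, with a 13-fold higher number from compound 1 to compound 2 (1.11 log units; beyond the scatter) on one side and a 14-fold lower number from compound 2 to compound 3 (1.14 log units; beyond the scatter) on the other.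

Compound 4 `CC1(C)CCC[C@]2(C)[C@@H](CC[C@@](C)(O)/C=C/c3ccc(C(=O)O)cc3)[C@](C)(O)CC[C@@H]12` carries carboxy in place of fluoro on an aromatic carbon, para to a large group: carboxy in place of fluoro on an aromatic carbon. Among the compounds with values here, no measured compound carries this group, so the evidence is indirect. Within the data shown here, the closest precedent is the exchange at the same place on the ring, where compound 2 and compound 3 are separated by a 14-fold lower number from compound 2 to compound 3 (1.14 log units; beyond the scatter). That step shows that the group at this place can move the number a long way in this assay. Among the measured compounds shown here, it also shows that the one other group measured there, in compound 2, sits far above fluoro. A rise is therefore expected, though smaller than the full gap, and with wide uncertainty. The expected change is a 3.9-fold higher number from compound 3 to compound 4 (0.59 log units; beyond the scatter). For compound 4 the estimated value is 12000 nM, with an expected range from 2500 nM to 50000 nM.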

Compound 4, half-maximal inhibitory concentration: 44300 nM
Compound 4: the middle estimate sits 3.7-fold (0.57 log units) below what was measured; measured number inside the range.
By their numbers in this assay, from the lowest: compounds 3 and 1 (each within the scatter of the next); then compounds 2 and 4 (each within the scatter of the next).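

In this assay the change from 4-fluorophenyl to 4-carboxyphenyl (a 14-fold higher number from compound 3 to compound 4 (1.16 log units; beyond the scatter)) shows that bromo is not alone: a second group on this aromatic carbon, para to a large group, also lies far from fluoro. Carboxy and bromo differ in what is counted for them, yet they stand level (a 1.0-fold higher number from compound 2 to compound 4 (0.01 log units; within the scatter)), so the compounds at this place fall into two levels rather than a graded series. The 2,6-dimethylphenyl compound, level with the 4-fluorophenyl compound, is also far from the new compound (a 13-fold higher number from compound 1 to compound 4 (1.12 log units; beyond the scatter)), so among these four compounds the two with bromo or carboxy form the high level and the other two the low one.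

The compounds shown leave open whether an amine, a methyl ester of the carboxylic acid, or chloro at this place would fall at the level of fluoro, at the level of bromo and carboxy, or somewhere else. Nothing available here accounts for why fluoro stands so far from the other two groups.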